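Swapping the nitro for two methoxy groups on the amide

A few compounds are considered here, and "the series" means these few. Any claim that something is new, unique, unknown or untested is made for them only; others in the source may bear on it.

Compound 1 `O=C(Nc1cc(-c2ccccc2)nn1-c1ccccc1)c1ccccc1` gives 4180 nM in an assay on HEK293 cells for displacement of a labelled ligand from metabotropic glutamate receptor 5 (Rattus norvegicus); on this read-out higher numbers stand for weaker inhibition and lower numbers for stronger inhibition. Compound 2 `O=C(Nc1cc(-c2ccccc2)nn1-c1ccccc1)c1cccc([N+](=O)[O-])c1`, which carries a nitro group, gives 2220 nM in this assay; the step of a 1.9-fold lower number from compound 1 to compound 2 (0.27 log units; within the scatter) lies within the scatter, so compound 2 has the lowest of the two numbers without standing apart. Compound 3 `O=C(Nc1cc(-c2ccccc2)nn1-c1ccccc1)c1cc([N+](=O)[O-])cc([N+](=O)[O-])c1` gives "not determined" (no result reported) in this assay, so no number is available for it. Compound 4 `COc1cc(OC)cc(C(=O)Nc2cc(-c3ccccc3)nn2-c2ccccc2)c1` differs from compound 2 by 3,5-dimethoxyphenyl in place of 3-nitrophenyl on a carbonyl carbon. Within the data shown here, no measured step touches a methoxy group, and the only step available, from hydrogen to nitro, stayed within the scatter, so compound 4 is expected to sit near compound 2, with the change a 1.4-fold higher number from compound 2 to compound 4 (0.13 log units; within the scatter) not beyond the scatter. Compound 4 is estimated at 3000 nM, between 1000 nM and 9000 nM.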

Compound 4, inhibition constant: > 10000 nM
Compound 4 was reported as a limit; the forecaster's own chance of this, stated with the estimate: 10%; middle value at least 3.3-fold (0.52 log units) away from the limit.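

Replacing 3-nitrophenyl with 3,5-dimethoxyphenyl on the carbonyl carbon gives an at least 4.5-fold higher number from compound 2 to compound 4 (0.65 log units; beyond the scatter), and replacing phenyl with it gives an at least 2.3-fold higher number from compound 1 to compound 4 (0.37 log units; beyond the scatter). The result for compound 4 in this assay is a limit and not a number: the limit of > 10000 nM in this assay, at which 1 of the 4 values shown sits. This position therefore responds to what it carries, which the step of a 1.9-fold lower number from compound 1 to compound 2 (0.27 log units; within the scatter), lying within the scatter, did not show. From the compounds shown here alone, how far compound 4 lies past its limit stays open. Also open, going by these compounds, are whether a single methoxy group gives the same change and how an amine or a carboxylic acid on this ring would read.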